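A Methyl Step Repeated on a Second Core

The source may report more compounds than this note shows. Statements on the series, on what has been measured and on what is new or still open speak of the compounds shown alone.

The measured compounds:
compound 1 `O=C(Oc1ccc2ccc(=O)oc2c1CN1CCc2ccccc2C1)c1ccccc1` gives > 100000 nM
compound 2 `Cc1cc(=O)oc2c(CN3CCc4ccccc4C3)c(OC(=O)c3ccccc3)ccc12` gives > 100000 nM
compound 3 `CC(=O)Oc1ccc2ccc(=O)oc2c1Cc1c(-c2ccccc2)[nH]c2ccccc12` gives > 100000 nM

The study tracks an ADME assay on MT4 cells (Homo sapiens) for cytotoxicity, read by MTT assay, with a stated time of 96 h; a higher number here means that more compound is tolerated, a lower number that less compound is tolerated. Compound 1 reaches only > 100000 nM, which is a limit of the assay rather than a number. Compound 2 likewise reaches > 100000 nM, again a limit. Between them stands the change (methyl in place of hydrogen on an aromatic carbon), and the two limits leave the step that the two limits leave unreadable from compound 1 to compound 2 unreadable. Compound 3 also sits at > 100000 nM, a limit. All three values therefore rest at the limit of > 100000 nM in this assay, at which 3 of the 3 values shown sit. The difference between the core of compound 1 and the core of compound 3 is not broken down here.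

Compound 4 `CC(=O)Oc1ccc2c(C)cc(=O)oc2c1Cc1c(-c2ccccc2)[nH]c2ccccc12` has not yet been measured. It differs from compound 3 by methyl in place of hydrogen on an aromatic carbon, the same change that carries compound 1 into compound 2, and the surroundings of the place are described in identical words for both pairs. Because compound 1 and compound 2 both rest at the limit of > 100000 nM in this assay, at which 3 of the 3 values shown sit, and compound 3 rests there as well, the step of a number no higher from compound 3 to compound 4 (the limit leaves the size open) is expected to be indistinguishable from zero within this assay. Compound 4 is therefore estimated at 100000 nM, with a likely range from 50000 nM to 200000 nM, and most probably the assay will again report only a limit for compound 4.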

Compound 4, half-maximal cytotoxic concentration: > 100000 nM
Compound 4: no number, only a limit (the forecaster's own chance of this, stated with the estimate: 85%); the middle value lies on the limit itself.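

In this assay compound 4 gives > 100000 nM as a limit of the assay, not a number. Compound 3 also rests at a limit, so no size can be read for the step between compound 3 and compound 4. All the compounds shown sit together: the limit of > 100000 nM in this assay, at which 4 of the 4 values shown sit. What they leave open is how far any of them lies from that limit, and whether methyl in place of hydrogen shifts the value on either core.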